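Adding bromo to compound 3: working notes

This account rests on a few compounds, and the source may have more. Where it says the series, first, only, none or still open, it means among the compounds named here.

Values in a functional assay on A549 cells (Homo sapiens) for antiproliferative activity, read by sulforhodamine B assay, with a stated time of 48 h; on this read-out higher numbers stand for weaker inhibition and lower numbers for stronger inhibition:
- compound 1 `COc1ccc(OC)c(/C=C/C(=O)/C=C(O)/C=C/c2cc(OC)ccc2OC)c1`: 16300 nM
- compound 2 `COc1cc(C=C(C(=O)/C=C/c2cccc(OC)c2OC)C(=O)/C=C/c2cccc(OC)c2OC)ccc1O`: 130 nM
- compound 3 `COc1cc(OC)c(/C=C/C(=O)C(=Cc2ccc(O)c(OC)c2)C(=O)/C=C/c2c(OC)cc(OC)cc2OC)c(OC)c1`: 580 nM

Compound 3 holds the middle place of the three, with a higher number than compound 2 and a lower number than compound 1, both gaps beyond the scatter. Compound 4 `COc1cc(OC)c(/C=C/C(=O)C(=Cc2cc(Br)c(O)c(OC)c2)C(=O)/C=C/c2c(OC)cc(OC)cc2OC)c(OC)c1` has bromo in place of hydrogen on an aromatic carbon, ortho to a hydroxy group and meta to a methoxy group: bromo in place of hydrogen on an aromatic carbon. Going by the values given here, no measured pair shows this change, so the expectation starts from compound 3 at 580 nM, and no step beyond the scatter is expected in this assay. The estimated change is a 1.5-fold lower number from compound 3 to compound 4 (0.16 log units; within the scatter). For compound 4 the estimated value is 400 nM, with an expected range from 150 nM to 1200 nM.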

Compound 4, half-maximal inhibitory concentration: 730 nM
The estimate for compound 4 lay 1.8-fold (0.26 log units) below the measured number; the range from low to high includes it.
By their numbers in this assay, from the lowest: compound 2; then compounds 3 and 4 (each within the scatter of the next); then compound 1.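

In this assay, the step from hydrogen to bromo on this aromatic carbon, ortho to a hydroxy group and meta to a methoxy group, is a 1.3-fold higher number from compound 3 to compound 4 (0.10 log units; within the scatter) and so does not separate the two compounds. This carbon of the 4-hydroxy-3-methoxyphenyl ring therefore accepts a single bromine atom with the read-out held within the scatter. No available measurement explains this result.

As far as these compounds go, it remains open whether an amine or a carboxylic acid at this carbon would give a step beyond the scatter. From the compounds shown here alone, the same bromo change on compound 2 also remains open.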